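Hydroxyphenyl for fluorophenyl: expected effect on solubility

The compounds below may be only part of what the source reports. "The series", "measured", "known", "first", "only" and "open" are said of these compounds alone.

Compound 1 `CCc1ccc(-c2nc3c(c(C)nn3-c3ccccc3)c(-c3ccccc3O)c2C#N)cc1`: 3100 nM
Compound 2 `CCc1ccc(-c2nc3c(c(C)nn3-c3ccccc3)c(-c3ccccc3F)c2C#N)cc1`: 1700 nM

In a physicochemical assay for solubility, read by spectrophotometry, in phosphate buffer, with a stated time of 18 h, at pH 7.4 (on this read-out lower numbers stand for lower solubility and higher numbers for higher solubility), compound 2 gives the lowest of the two numbers, and its nearest neighbour is compound 1, with a 1.8-fold lower number from compound 1 to compound 2 (0.26 log units; within the scatter) separating them, a step within the scatter. Compound 3 `CCc1ccc(-c2nc3c(c(C)nn3-c3ccccc3)c(-c3ccc(O)cc3)c2C#N)cc1` has not yet been measured in this assay. It differs from compound 2 in one place: 4-hydroxyphenyl in place of 2-fluorophenyl on an aromatic carbon. Among the measured compounds shown here, the only measured step that bears on this change is the one between compound 1 and compound 2, a 1.8-fold lower number from compound 1 to compound 2 (0.26 log units; within the scatter), where fluoro took the place of hydroxy on an aromatic carbon; compound 3 runs that exchange backwards, though its hydroxyphenyl group is not the same group as that of compound 1. A step of about that size, in the upward direction but still within the scatter, is therefore expected: a 1.6-fold higher number from compound 2 to compound 3 (0.22 log units; within the scatter). Compound 3 is estimated at 2800 nM, within a range of 1200 nM to 6500 nM.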

Compound 3, solubility: 5700 nM
The estimate for compound 3 lay 2.0-fold (0.31 log units) below the measured number; measured number inside the range.
By their numbers in this assay, from the lowest: compounds 2, 1 and 3 (each within the scatter of the next, the first and the last beyond it).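

In this assay, among the compounds shown here, 4-hydroxyphenyl in place of 2-fluorophenyl on this aromatic carbon, ortho to a cyano group, gives a 3.4-fold higher number from compound 2 to compound 3 (0.53 log units; beyond the scatter) and so provides the first step at this position that lies beyond the scatter. Exchanging 2-hydroxyphenyl for 4-hydroxyphenyl gives a 1.8-fold higher number from compound 1 to compound 3 (0.26 log units; within the scatter) and stays within the scatter, so these two hydroxyphenyl groups cannot be told apart on this read-out. Compound 2 is thus clearly separated from compound 3, but not from compound 1. Nothing measured here gives a cause for these steps.

On these data alone, what an unsubstituted phenyl group would give at this position remains open. So does the effect of placing an amine or a carboxylic acid at the 4-position of this phenyl group in place of the hydroxy group.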